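From isopropyl to 2-hydroxypropyl on an aromatic nitrogen

A few compounds are considered here, and "the series" means these few. Any claim that something is new, unique, unknown or untested is made for them only; others in the source may bear on it.

In a functional assay on KG-1 cells (Homo sapiens) for antiproliferative activity, read by CCK-8 assay, with a stated time of 72 h (a higher number here means a weaker inhibitor, a lower number a stronger inhibitor), compound 1 `Cc1ccc(C(=O)Nc2cccc(C(F)(F)F)c2)cc1-c1ccc2c(-c3cnn(C)c3)n[nH]c2c1` gives 65.7 nM, compound 2 `CCCn1cc(-c2n[nH]c3cc(-c4cc(C(=O)Nc5cccc(C(F)(F)F)c5)ccc4C)ccc23)cn1` gives 358 nM and compound 3 `Cc1ccc(C(=O)Nc2cccc(C(F)(F)F)c2)cc1-c1ccc2c(-c3cnn(C(C)C)c3)n[nH]c2c1` gives 452 nM. Compound 3 therefore stands level with compound 2 within the scatter, and both stand beyond the scatter from compound 1: the steps are a 5.4-fold higher number from compound 1 to compound 2 (0.74 log units; beyond the scatter) and a 6.9-fold higher number from compound 1 to compound 3 (0.84 log units; beyond the scatter). Compound 4 `Cc1ccc(C(=O)Nc2cccc(C(F)(F)F)c2)cc1-c1ccc2c(-c3cnn(CC(C)O)c3)n[nH]c2c1` has 2-hydroxypropyl in place of isopropyl on an aromatic nitrogen. Among the measured compounds shown here, no measured compound carries this group, so the evidence is indirect. The closest guide is the propyl-to-isopropyl step, a 1.3-fold higher number from compound 2 to compound 3 (0.10 log units; within the scatter), which lies within the scatter. No step beyond the scatter is therefore expected in this assay, and the expected step is a 1.5-fold lower number from compound 3 to compound 4 (0.18 log units; within the scatter). The estimated value for compound 4 is 300 nM, with an expected range of 110 nM to 800 nM.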

Compound 4, half-maximal inhibitory concentration: 339 nM
For compound 4 the middle estimate is 1.1-fold (0.05 log units) below the measured one, and the stated range covers the measured number.
By their numbers in this assay, from the lowest: compound 1; then compounds 4, 2 and 3 (each within the scatter of the next).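

In this assay, 2-hydroxypropyl on the aromatic nitrogen reads level with isopropyl (a 1.3-fold lower number from compound 3 to compound 4 (0.12 log units; within the scatter)) and with propyl (a 1.1-fold lower number from compound 2 to compound 4 (0.02 log units; within the scatter)), so adding a hydroxy, with its hydrogen-bond donor and acceptor, gives no step beyond the scatter at this position. The gap to the methyl group of compound 1 remains (a 5.2-fold higher number from compound 1 to compound 4 (0.71 log units; beyond the scatter)), and propyl, isopropyl and 2-hydroxypropyl all stand together on the far side of it. No evidence on hand accounts for this result.

As far as these compounds go, whether an amine or a carboxylic acid on this chain would stay at the same level remains open. So does the reading for ethyl, the group that would fall between methyl and propyl in chain length.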